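Oxamide in place of urea at the piperidine nitrogen

A few compounds are considered here, and "the series" means these few. Any claim that something is new, unique, unknown or untested is made for them only; others in the source may bear on it.

Three compounds share one core. Compound 1 `CC(=O)N1CCC(C(=O)N2CC[C@H](C(=O)N(C)Cc3cc(C(F)(F)F)cc(C(F)(F)F)c3)[C@@H](c3ccc(C)cc3)C2)CC1` gives 0.18 nM in an assay on IM-9 cells for displacement of a labelled ligand from Substance-P receptor (Homo sapiens), read by scintillation counting, with a stated time of 30 min (on this read-out lower numbers stand for stronger inhibition and higher numbers for weaker inhibition), and compound 2 `CC(=O)N1CCC(C(=O)N2CC[C@H](C(=O)N(C)Cc3cc(C(F)(F)F)cc(C(F)(F)F)c3)[C@@H](c3cccc(C)c3)C2)CC1` gives 0.14 nM; the step of a 1.3-fold lower number from compound 1 to compound 2 (0.11 log units; within the scatter) stays within the scatter. Compound 3 `CNC(=O)N1CC[C@H](C(=O)N(C)Cc2cc(C(F)(F)F)cc(C(F)(F)F)c2)[C@@H](c2ccc(F)cc2C)C1` gives 0.048 nM, the lowest number of the three, beyond the scatter from compound 2 and from compound 1, so compound 3 stands as the strongest of the measured set.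

Compound 4 `CNC(=O)C(=O)N1CC[C@H](C(=O)N(C)Cc2cc(C(F)(F)F)cc(C(F)(F)F)c2)[C@@H](c2ccc(F)cc2C)C1` departs from compound 3 by methylcarbamoyl in place of methylamino on a carbonyl carbon. For the measured compounds named here, none of the measured steps touches this position: the only step on record, the one from compound 1 to compound 2, concerns the aryl group on the saturated ring, so it offers no guide to the change at the carbonyl carbon. Going by the values given here, with no comparable step to lean on, the expectation for compound 4 rests on compound 3 alone, and the step is estimated as a 2.1-fold higher number from compound 3 to compound 4 (0.32 log units; beyond the scatter), with wide uncertainty. Compound 4 is therefore expected to give about 0.1 nM in this assay, within a range from 0.03 nM to 0.4 nM.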

Compound 4, half-maximal inhibitory concentration: 0.11 nM
Compound 4: the middle estimate sits 1.1-fold (0.04 log units) below what was measured; the range from low to high includes it.
By their numbers in this assay, from the lowest: compound 3; then compounds 4, 2 and 1 (each within the scatter of the next).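

For the compounds shown here, the step at the carbonyl carbon gives the first reading of this position: in this assay, methylcarbamoyl in place of methylamino gives a 2.3-fold higher number from compound 3 to compound 4 (0.36 log units; beyond the scatter), a modest weakening that lies beyond the scatter. The position therefore accepts the longer group, which adds a carbonyl to the chain, and compound 4 still gives 0.11 nM. The data shown hold no evidence that bears on this result.

Going by these compounds, what an amine, a carboxylic acid or a longer chain would do on this carbonyl carbon remains open, as a single step cannot show a trend at this position. On these data alone, it is also open whether the same change would give a similar step with the 3-methylphenyl group of compound 2 on the saturated ring carbon.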